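A few compounds are considered here, and "the series" means these few. Any claim that something is new, unique, unknown or untested is made for them only; others in the source may bear on it.

Compound 1 `COc1ccc(C#Cc2nc(C(N)=O)nn2COCCO)cc1` and compound 2 `NC(=O)c1nc(C#Cc2cccc(F)c2)n(COCCO)n1` share the same core and differ only in the group on the triple-bonded carbon. Among the measured compounds shown here, in an ADME assay on Huh-5-2 cells (Homo sapiens) for cytotoxicity (on this read-out lower numbers stand for higher toxicity in this test and higher numbers for lower toxicity in this test), compound 2 gives 29 ug/mL, the only plain number in this small set. Compound 1 reaches only a limit of the assay in this assay, namely > 50 ug/mL. That value is the limit of > 50 ug/mL in this assay, at which 1 of the 2 values shown sits. Compound 3 `NC(=O)c1nc(C#CC2(O)CCCCC2)n(COCCO)n1` carries 1-hydroxycyclohexyl in place of 3-fluorophenyl on a triple-bonded carbon. For the measured compounds named here, no measured pair differs in a single place, so the size of such a step has not been seen. The step is nonetheless expected to run toward lower toxicity, about a 1.7-fold higher number from compound 2 to compound 3 (0.24 log units; within the scatter). Compound 3 is therefore estimated at 50 ug/mL, somewhere between 22 ug/mL and 110 ug/mL.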

Compound 3, half-maximal cytotoxic concentration: > 50 ug/mL
Compound 3 gave a limit, no number; the forecaster's own chance of this, stated with the estimate: 55%; the middle value sits exactly at the limit.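

In this assay, among the compounds shown here, replacing 3-fluorophenyl with 1-hydroxycyclohexyl on a triple-bonded carbon gives the first step in one place: an at least 1.7-fold higher number from compound 2 to compound 3 (0.23 log units; that floor lies within the scatter). This is only a floor, so the change cannot be told apart from the scatter, and its true size cannot be read. The read-out now ends at a limit for most of this small set: the limit of > 50 ug/mL in this assay, at which 2 of the 3 values shown sit.

On these data alone, it remains open how a plain cyclohexyl group would read at this position, which would separate the hydroxyl from the change of ring. An amine or a longer chain on the triple-bonded carbon also remains untested in the compounds shown.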